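The source may report more compounds than this note shows. Statements on the series, on what has been measured and on what is new or still open speak of the compounds shown alone.

Measured compounds and values:
- Compound 1 `C=CC1C(=O)N(c2cc(OC)c(OC)c(OC)c2)C1c1ccc(OC)cc1`: in a functional assay on MCF7 cells (Homo sapiens) for inhibition, read by resazurin assay, with a stated time of 72 h (a higher number here means a weaker inhibitor, a lower number a stronger inhibitor), compound 1 gives 17 nM.
- Compound 2 `COc1ccc(C2C(O)C(=O)N2c2cc(OC)c(OC)c(OC)c2)cc1`: in this assay compound 2 gives 4 nM.

Going by the values given here, compound 2 holds the lowest of the two numbers in this assay; its nearest neighbour is compound 1, and the only measured step runs a 4.3-fold lower number from compound 1 to compound 2 (0.63 log units; beyond the scatter), a change on the saturated ring carbon of the shared core.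

Compound 3 `CCOc1ccc(C2C(O)C(=O)N2c2cc(OC)c(OC)c(OC)c2)cc1` differs from compound 2 in one place: methyl in place of hydrogen on a saturated chain carbon bound to an oxygen on an aromatic ring. Among the compounds with values here, no measured step touches this position; the single step from compound 1 to compound 2 alters the saturated ring carbon, not the aromatic ether, so it offers no direct guide to the size or direction of the present change. With nothing in the series speaking to a methoxy-to-ethoxy exchange, the working assumption is a step that does not exceed the scatter, and the estimate for compound 3 is accordingly anchored on compound 2: the expected step is a 1.3-fold higher number from compound 2 to compound 3 (0.10 log units; within the scatter). Compound 3 is expected to give 5 nM in this assay, within a range of 1.5 nM to 16 nM.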

Compound 3, half-maximal inhibitory concentration: 7 nM
Compound 3: the middle estimate sits 1.4-fold (0.15 log units) below what was measured, within the range that was stated.
By their numbers in this assay, from the lowest: compounds 2 and 3 (each within the scatter of the next); then compound 1.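

In this assay, the aromatic ether now has its first measured step, the change from methoxy to ethoxy: a 1.8-fold higher number from compound 2 to compound 3 (0.24 log units; within the scatter). This step lies within the scatter, so the assay does not separate compound 2 from compound 3, and the 4-ethoxyphenyl group reads the same as the 4-methoxyphenyl group on the shared core with the ring hydroxy in place. Nothing at hand bears on why this exchange leaves the reading within the scatter.

The compounds shown leave open how far this tolerance extends, since a single methyl in place of hydrogen says nothing about a longer chain such as propoxy or butoxy, a branched isopropoxy, or a group of another kind at this position, such as a free hydroxy or an amine. Going by these compounds alone, also open is whether the same exchange from methoxy to ethoxy would read the same on the vinyl-bearing core of compound 1, as the only measured step at this position stands on the hydroxy-bearing core.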